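The compounds below may be only part of what the source reports. "The series", "measured", "known", "first", "only" and "open" are said of these compounds alone.

Measured compounds in an ADME assay on HepG2 cells (Homo sapiens) for cytotoxicity, read by luminescence, CellTiter-Glo and ATP content, with a stated time of 72 h; a higher number here means that more compound is needed for the effect, a lower number that less compound is needed:
- compound 1 `COc1ccc(Oc2ccc3c(NCCCNCc4cc(F)ccc4OC)ccnc3c2)cc1`: 7000 nM
- compound 2 `COc1cccc(Oc2ccc3c(NCCCNCc4cc(F)ccc4OC)ccnc3c2)c1`: 7100 nM
- compound 3 `COc1ccc(F)cc1CNCCCNc1ccnc2cc(Oc3ccc(F)cc3)ccc12`: 6600 nM

The three measured compounds share one core and differ only at the aryl ether and at the benzylamine end. For the measured compounds named here, the two steps among them that change the aryl ether, a 1.0-fold higher number from compound 1 to compound 2 (0.01 log units; within the scatter) and a 1.1-fold lower number from compound 2 to compound 3 (0.03 log units; within the scatter), and the one that changes the benzylamine end, a 1.1-fold lower number from compound 1 to compound 3 (0.03 log units; within the scatter), all stay within the scatter. Compound 3 therefore stands at a number that the other two cannot be told apart from; the three values are effectively one.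

Compound 4 `COc1ccc(F)cc1CNCCCNc1ccnc2cc(-c3ccc(C(C)(C)C)cc3)ccc12` is formed from compound 3 by a single change: 4-(tert-butyl)phenyl in place of 4-fluorophenoxy on an aromatic carbon. Going by the values given here, none of the measured steps bears on this change. Among the compounds with values here, the measured steps show only that swapping one aryl ether for another, or a fluoro for a methoxy at the benzylamine end, leaves the number where it was; replacing the ether oxygen by a direct aryl link with a tert-butyl has no precedent here. On these data alone, compound 4 is expected to sit near the shared value, with no shift beyond the scatter but a wide range to reflect the untested change, so the estimate for compound 4 is 6000 nM (range 2500 nM to 14000 nM), a step of a 1.1-fold lower number from compound 3 to compound 4 (0.04 log units; within the scatter).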

Compound 4, half-maximal effective concentration: 620 nM
Estimate against measurement, compound 4: 9.7-fold (0.99 log units) above; the whole stated range lies above it.
By their numbers in this assay, from the lowest: compound 4; then compounds 3, 1 and 2 (each within the scatter of the next).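

In this assay, 4-(tert-butyl)phenyl in place of 4-fluorophenoxy on the aromatic carbon gives an 11-fold lower number from compound 3 to compound 4 (1.03 log units; beyond the scatter), whereas every earlier step stayed within the scatter. The same exchange, read from the other two aryl ethers, gives an 11-fold lower number from compound 2 to compound 4 (1.06 log units; beyond the scatter) and an 11-fold lower number from compound 1 to compound 4 (1.05 log units; beyond the scatter), so the three starting points lead to steps of a like size. Exchanges among the aryl ethers had left the number in place, but this position does respond when 4-(tert-butyl)phenyl takes the place of the aryl ether. Nothing measured here accounts for this shift.

The compounds shown leave open whether the step belongs to the loss of the ether oxygen or to the tert-butyl group: a 4-(tert-butyl)phenoxy group and an unsubstituted phenyl on the same aromatic carbon would separate the two. They also leave open how far the number would follow other groups on that phenyl ring, such as a trifluoromethyl, an amine or a carboxylic acid, and whether a fluoro in place of the methoxy at the benzylamine end would still leave the number unmoved with 4-(tert-butyl)phenyl in place.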